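The compounds below may be only part of what the source reports. "The series", "measured", "known", "first", "only" and "open" are said of these compounds alone.

Measured so far in a functional assay on cells for agonist activity at G-protein coupled receptor 52 (Homo sapiens), read by AlphaScreen and cAMP accumulation, with a stated time of 30 min; a higher number here means a larger maximal response, a lower number a smaller maximal response:

Compound 1 `COc1cccc(Cc2nc(C)c(-c3ccc(C(N)=O)c(C)c3)s2)c1`: compound 1 gives 85%.
Compound 2 `Cc1cc(-c2sc(Cc3ccccc3Cl)nc2C)ccc1C(N)=O`: compound 2 gives 51%.
Compound 3 `Cc1cc(-c2sc(Cc3ccc(Cl)cc3)nc2C)ccc1C(N)=O`: compound 3 gives 60%.

Compound 3 stands second of the three numbers in this assay. Its nearest neighbour is compound 2, the gap being a number 9 percentage points higher from compound 2 to compound 3 (within the scatter). Among the measured compounds shown here, the one step that lies beyond the scatter in its favour is toward compound 1, a number 25 percentage points lower from compound 1 to compound 3 (beyond the scatter).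

Compound 4 `Cc1cc(-c2sc(Cc3cc(F)cc(Cl)c3)nc2C)ccc1C(N)=O` is not yet measured. The change from compound 3 is 3-chloro-5-fluorophenyl in place of 4-chlorophenyl on a saturated chain carbon bound to an aromatic carbon.

For the measured compounds named here, the steps that bear on it are those that alter the same group on the same saturated chain carbon: a number 34 percentage points lower from compound 1 to compound 2 (beyond the scatter), a number 25 percentage points lower from compound 1 to compound 3 (beyond the scatter) and a number 9 percentage points higher from compound 2 to compound 3 (within the scatter). Moving the chlorine around the ring gave a shift within the scatter; exchanging 3-methoxyphenyl for either chlorophenyl lowered the response beyond it. Going by the values given here, no measured step adds a second halogen, so compound 4 is expected to sit near compound 3, with a step of a number 3 percentage points lower from compound 3 to compound 4 (within the scatter) in this assay, not beyond the scatter.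

The estimate for compound 4 in this assay is 57%, expected to fall between 40% and 75%.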

Compound 4, largest response reached (Emax), in percent of the reference or control that the assay uses: 88%
Compound 4: middle estimate off by 31 percentage points, on the low side; the measured number lies above the stated range.
By their numbers in this assay, from the lowest: compounds 2 and 3 (each within the scatter of the next); then compounds 1 and 4 (each within the scatter of the next).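

At the saturated chain carbon bound to an aromatic carbon, this assay shows that a halogen-bearing ring need not stay at the level of the two chlorophenyl compounds: 3-chloro-5-fluorophenyl gives a number 28 percentage points higher from compound 3 to compound 4 (beyond the scatter) and a number 37 percentage points higher from compound 2 to compound 4 (beyond the scatter). Among the compounds shown here, the 3-methoxyphenyl group is also no longer the only group here with a high response, as the comparison with it gives a number 3 percentage points higher from compound 1 to compound 4 (within the scatter). No measurement on hand accounts for this rise.

The compounds shown leave open whether 3-chlorophenyl or 3-fluorophenyl alone would hold the response of the 3-chloro-5-fluorophenyl ring, with the two halogens separated. They also leave open how this position would respond to a ring carrying an amine or a carboxylic acid, or to a longer chain in place of the single saturated carbon.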